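A few compounds are considered here, and "the series" means these few. Any claim that something is new, unique, unknown or untested is made for them only; others in the source may bear on it.

Measured so far:

Compound 1, `COc1cc(C2=C(c3cc(C)c(OC)c(C)c3)C(O)CC2=O)cc(OC)c1OC`, a limit of the assay: > 100 ug/mL
Compound 2, `COc1cc(C2=C(c3cc(C)c(OC)c(C)c3)C(OC(C)=O)CC2=O)cc(OC)c1OC`, a limit of the assay: > 100 ug/mL
Compound 3, `COc1ccc(C2=C(c3cc(OC)c(OC)c(OC)c3)C(=O)C(O)C2)cc1Cl`: 20 ug/mL

All three were tested in an ADME assay on ECV-304 cells (Homo sapiens) for cytotoxicity, read by MTT assay, with a stated time of 72 h; on this read-out higher numbers stand for weaker inhibition and lower numbers for stronger inhibition. Going by the values given here, for compound 1 and compound 2 the value is a limit rather than a number, and compound 3 gives the only number in the set. The two cores, that of compound 1 and that of compound 3, differ in more than one place, and the difference between them is not broken down here.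

Compound 4, `COc1ccc(C2=C(c3cc(OC)c(OC)c(OC)c3)C(=O)C(OC(C)=O)C2)cc1Cl`, has not been measured. It arises from compound 3 by a single change, (acetyl in place of hydrogen on an oxygen on a saturated carbon). The same change, word for word at the same kind of place, is seen between compound 1 and compound 2: acetyl in place of hydrogen on an oxygen on a saturated carbon. Its effect there is a step that the two limits leave unreadable from compound 1 to compound 2, because the limit of > 100 ug/mL in this assay, at which 2 of the 3 values shown sit, both values sit at the limit and the size of the step cannot be read.

So the step from compound 3 to compound 4 rests on one number only, that of compound 3 in this assay, 20 ug/mL, with no readable precedent for the change. The estimate therefore stays close to compound 3, with wide room in both directions. Compound 4 is expected to give about 25 ug/mL, somewhere between 8 ug/mL and 80 ug/mL. The step expected here is a 1.3-fold higher number from compound 3 to compound 4 (0.10 log units; within the scatter).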

Compound 4, half-maximal inhibitory concentration: 3.5 ug/mL
Estimate against measurement, compound 4: 7.1-fold (0.85 log units) above; the measured number lies below the stated range.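

In this assay, the change from hydroxy to acetoxy gives a 5.7-fold lower number from compound 3 to compound 4 (0.76 log units; beyond the scatter) and so goes with stronger inhibition on this core, although the step is only modest in size. The same change on the core of compound 1 cannot be read, because compound 1 and compound 2 each give a limit of the assay and not a number: the limit of > 100 ug/mL in this assay, at which 2 of the 4 values shown sit. This leaves a single readable pair, which shows what the change did on one core but does not show that the change carries over to another core, and it sets no rule for the series.

The compounds shown leave open whether this step is tied to acetyl itself or would also appear with a longer chain on the same oxygen, such as butyryl, or with a simple methyl ether there. They also leave open what an amine or a carboxylic acid at that place would do, and whether any such group would bring the core of compound 1 into a range where a true number can be read.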